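Changing the aryl arm once more on a shared core

A few compounds are considered here, and "the series" means these few. Any claim that something is new, unique, unknown or untested is made for them only; others in the source may bear on it.

In a functional assay on HL-60 cells (Homo sapiens) for antiproliferative activity, with a stated time of 72 h (a lower number here means a stronger inhibitor, a higher number a weaker inhibitor), compound 1 `OC[C@H]1O[C@@H](n2cnc3c(NCc4ccc(F)cc4)ncnc32)[C@H](O)[C@@H]1O` gives 1200 nM, while compound 2 `COc1cc(CNc2ncnc3c2ncn3[C@@H]2O[C@H](CO)[C@@H](O)[C@H]2O)cc(OC)c1` gives 20200 nM, the highest of the two numbers seen so far. Among the measured compounds shown here, the only measured step, a 17-fold higher number from compound 1 to compound 2 (1.23 log units; beyond the scatter), shows that the aryl group in this place can shift the number a great deal. Compound 3 `Cc1cccc(CNc2ncnc3c2ncn3[C@@H]2O[C@H](CO)[C@@H](O)[C@H]2O)c1O` alters that group again: 2-hydroxy-3-methylphenyl in place of 3,5-dimethoxyphenyl on a saturated chain carbon bound to a nitrogen on an aromatic ring. For the measured compounds named here, no measured step covers this exact replacement, so the expectation rests on compound 2 standing at the top and on compound 1 giving 1200 nM with a smaller aryl group. A step of a 3.4-fold lower number from compound 2 to compound 3 (0.53 log units; beyond the scatter) is expected. Compound 3 is therefore estimated at 6000 nM, within 1200 nM to 30000 nM.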

Compound 3, half-maximal inhibitory concentration: 15000 nM
Estimate against measurement, compound 3: 2.5-fold (0.40 log units) below; the measured number falls inside the stated range.
By their numbers in this assay, from the lowest: compound 1; then compounds 3 and 2 (each within the scatter of the next).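

In this assay, the step from 3,5-dimethoxyphenyl to 2-hydroxy-3-methylphenyl is a 1.3-fold lower number from compound 2 to compound 3 (0.13 log units; within the scatter) and so separates neither group from the other at this place. The 4-fluorophenyl group of compound 1 stays apart from both, as a 13-fold higher number from compound 1 to compound 3 (1.10 log units; beyond the scatter) now joins the earlier large step, so that gap is not tied to the 3,5-dimethoxyphenyl group alone. From the compounds shown here alone, whether an amine or a carboxylic acid on the aryl ring would give a number near that of compound 1 remains open. No data given here explain why these numbers differ.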